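The compounds below may be only part of what the source reports. "The series", "measured", "known", "first", "only" and "open" are said of these compounds alone.

Series notes. Compound 1 `[N-]=[N+]=NCCOCCOCCO[Si]1(OCCOCCOCCN=[N+]=[N-])n2c3c4ccccc4c2/N=C2\N=C(/N=c4/c5ccccc5/c(n41)=N/C1=N/C(=N\3)c3ccccc31)c1ccccc12` and compound 2 `[N-]=[N+]=NCCOCCO[Si]1(OCCOCCO)n2c3c4ccccc4c2/N=C2\N=C(/N=c4/c5ccccc5/c(n41)=N/C1=N/C(=N\3)c3ccccc31)c1ccccc12` share one core. In a functional assay on MCF7 cells (Homo sapiens) for cytotoxicity, read by MTT assay, with a stated time of 24 h (a higher number here means a weaker inhibitor, a lower number a stronger inhibitor), compound 1 gives 11 nM, while compound 2 gives 2.6 nM, the lowest of the two numbers, with compound 1 standing beyond the scatter above it. Compound 3 `[N-]=[N+]=NCCOCCO[Si]1(OCCOCCN=[N+]=[N-])n2c3c4ccccc4c2/N=C2\N=C(/N=c4/c5ccccc5/c(n41)=N/C1=N/C(=N\3)c3ccccc31)c1ccccc12` is not yet measured; it differs from compound 2 by azido in place of hydroxy on a saturated chain carbon, two bonds along the chain from an oxygen on a saturated carbon. Since compound 1 also carries two azido groups and shows 11 nM, a moderate rise is expected from compound 2 to compound 3, a 2.3-fold higher number from compound 2 to compound 3 (0.36 log units; beyond the scatter). Compound 3 is estimated at 6 nM in this assay, within 2 nM to 20 nM.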

Compound 3, half-maximal inhibitory concentration: 4.4 nM
Compound 3: the middle estimate sits 1.4-fold (0.13 log units) above what was measured, within the range that was stated.
By their numbers in this assay, from the lowest: compounds 2 and 3 (each within the scatter of the next); then compound 1.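

In this assay, the exchange of hydroxy for azido on a saturated chain carbon, two bonds along the chain from an oxygen on a saturated carbon, gives a 1.7-fold higher number from compound 2 to compound 3 (0.23 log units; within the scatter), so compound 2 and compound 3 cannot be told apart. At this position, hydroxy is therefore not required to keep the number in this range, and azido serves equally well on this core. No measurement here bears on what lies behind this result. On these data alone, whether an amine or a carboxylic acid at the same place would also hold the number remains open.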